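Notes on a chain and an aryl change in one series

The source may report more compounds than this note shows. Statements on the series, on what has been measured and on what is new or still open speak of the compounds shown alone.

Measured so far in an assay on isolated protein for displacement of a labelled ligand from corticotropin-releasing factor receptor 1 (Rattus norvegicus); on this read-out lower numbers stand for stronger inhibition and higher numbers for weaker inhibition:
- compound 1 `Cc1nc(Nc2c(Cl)cc(C(F)(F)F)cc2Cl)c(=O)n(C(C)C2CC2)n1` gives 14 nM
- compound 2 `CCC(C1CC1)n1nc(C)nc(Nc2c(Cl)cc(C(F)(F)F)cc2Cl)c1=O` gives 6.3 nM
- compound 3 `COCC(C1CC1)n1nc(C)nc(Nc2c(Cl)cc(C(F)(F)F)cc2Cl)c1=O` gives 11 nM

Within the data shown here, compound 2 stands lowest of the three numbers; the gap to compound 3 lies within the scatter, so the two are not told apart, and only the step of a 2.2-fold lower number from compound 1 to compound 2 (0.35 log units; beyond the scatter) lies beyond it. The other steps, a 1.3-fold lower number from compound 1 to compound 3 (0.10 log units; within the scatter) and a 1.7-fold higher number from compound 2 to compound 3 (0.24 log units; within the scatter), are both within the scatter. All three steps concern the saturated chain carbon alone; the aromatic ring and its substituents are the same in compounds 1, 2 and 3.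

Compound 4 `CCC(C1CC1)n1nc(C)nc(Nc2c(Cl)cc(OC(F)F)cc2Cl)c1=O` differs from compound 2 by difluoromethoxy in place of trifluoromethyl on an aromatic carbon. Among the measured compounds shown here, no measured step touches this position, so there is no step of this kind to lean on. With the chain of compound 2 retained and a group of the same size entering at the aromatic carbon, a step in this assay of no more than the scatter is expected, with no direction claimed, that is a 1.3-fold higher number from compound 2 to compound 4 (0.10 log units; within the scatter). Compound 4 is therefore estimated at 8 nM, with a range from 3 nM to 25 nM.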

Compound 4, half-maximal inhibitory concentration: 2.1 nM
Compound 4: middle estimate off by 3.8-fold (0.58 log units), on the high side; the whole stated range lies above it.
By their numbers in this assay, from the lowest: compound 4; then compounds 2, 3 and 1 (each within the scatter of the next, the first and the last beyond it).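

The aromatic carbon para to a large group, held as trifluoromethyl through compounds 1, 2 and 3, now proves responsive in this assay: with the chain of compound 2 retained, the change gives a 3.0-fold lower number from compound 2 to compound 4 (0.48 log units; beyond the scatter) and so lies beyond the scatter. Trifluoromethyl and difluoromethoxy have the same heavy-atom count, yet they are not interchangeable at this position on this read-out; by the counts, the entering group brings an oxygen and a hydrogen-bond acceptor. Nothing available here bears on why the number moves with this change.

The compounds shown pair this aryl change with one chain only, so it remains open whether it carries over to the chains of compound 1 and compound 3. Also open, as far as these compounds go, is how methoxy, a nitrile or a longer fluorinated ether would read at this aromatic carbon.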